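Two halogen patterns on the anilino ring of one core

The compounds below may be only part of what the source reports. "The series", "measured", "known", "first", "only" and "open" are said of these compounds alone.

The set shares a single core, seen in compound 1 `Cc1n[nH]c2ccc(-c3nc4cnc(N5CCN(C)CC5)cn4c3Nc3ccc(Cl)cc3F)cc12` and compound 2 `Cc1n[nH]c2ccc(-c3nc4cnc(N5CCN(C)CC5)cn4c3Nc3ccc(F)c(Cl)c3)cc12`, the two differing only in how the halogens are placed on the aryl group of the amine. For compound 1 the entry in a functional assay on CWR22R cells (Homo sapiens) for inhibition, with a stated time of 120 h, tested at 10 uM (on this read-out higher numbers stand for more inhibition at the one concentration tested (going by the name of the read-out) and lower numbers for less inhibition), reads "not determined" (no result reported), so no result is available for it. In this assay, among the measured compounds shown here, compound 2 gives 0.82%, the only number available here, so compound 2 stands alone and no comparison between measured compounds can be drawn. Compound 3 `Cc1n[nH]c2ccc(-c3nc4cnc(N5CCN(C)CC5)cn4c3Nc3cc(Cl)ccc3Cl)cc12` is not yet measured. Relative to compound 2 it carries 2,5-dichlorophenyl in place of 3-chloro-4-fluorophenyl on a nitrogen on an aromatic ring. For the measured compounds named here, with one measured value and no measured step to calibrate the size of such a change, the step from compound 2 to compound 3 is expected to stay within the usual scatter of this assay, and the expected step is a number 4.2 percentage points higher from compound 2 to compound 3 (within the scatter). Compound 3 is accordingly estimated to give 5% in this assay, with a range from -10% to 25% that mainly reflects the uncertainty of a single-concentration read-out sitting close to the bottom of its scale.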

Compound 3, a percentage reported as inhibition, at one concentration (the size of the read-out at that concentration, not a potency): 3.8%
Estimate against measurement, compound 3: 1.2 percentage points above; low and high end bracket the measured number.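

In this assay, among the compounds shown here, replacing 3-chloro-4-fluorophenyl with 2,5-dichlorophenyl on a nitrogen on an aromatic ring gives a number 3 percentage points higher from compound 2 to compound 3 (within the scatter), the first step that can be read at this position. It shows that this exchange, which keeps the count of heavy atoms and the single six-membered aromatic ring of carbon only, separates the two compounds by no more than the usual scatter, so that the read-out does not tell these two halogen patterns apart at the one concentration tested. No measured information is available that could account for this result.

The compounds shown leave open whether a group of another kind on this aryl ring, such as an aminomethyl group, a carboxylic acid or a methoxy group in place of the halogens, would move the read-out beyond the scatter. The halogen pattern of compound 1 also stays unplaced, since its entry reads "not determined" (no result reported), and a single concentration cannot show whether compound 2 and compound 3 would still match at higher concentrations.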